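A few compounds are considered here, and "the series" means these few. Any claim that something is new, unique, unknown or untested is made for them only; others in the source may bear on it.

Measured in a functional assay on MDA-MB-231 cells (Homo sapiens) for inhibition, read by sulforhodamine B assay, with a stated time of 48 h (a lower number here means a stronger inhibitor of growth, a higher number a weaker inhibitor of growth), so far:
- compound 1 (`O=C(O)c1cn(C2CC2)c2cc(N3CCN(C(=O)CCSc4nnnn4-c4ccc(Br)cc4)CC3)c(F)cc2c1=O`) gives <= 100 nM
- compound 2 (`CCn1cc(C(=O)O)c(=O)c2cnc(N3CCN(C(=O)CCSc4nnnn4-c4ccc(Br)cc4)CC3)nc21`) gives 220 nM

Compound 1 stands at <= 100 nM, which is a limit and not an exact number.

Compound 3 (`O=C(O)c1cn(C2CC2)c2cc(N3CCN(C(=O)CCSc4nnnn4Cc4ccccc4)CC3)c(F)cc2c1=O`) keeps the rest of compound 1 and changes one group: benzyl in place of 4-bromophenyl on an aromatic nitrogen. In words, benzyl takes the place of 4-bromophenyl on an aromatic nitrogen. Among the compounds with values here, no measured pair of compounds shows this change, so any forecast is uncertain. A modest loss of strength in this assay is expected, and the estimated step is an at least 1.5-fold higher number from compound 1 to compound 3 (0.17 log units; that floor lies within the scatter). Compound 3 is estimated at 150 nM, with an expected range of 40 nM to 600 nM.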

Compound 3, concentration for 50% growth inhibition: <= 100 nM
Compound 3: a limit, no number (the forecaster's own chance of this, stated with the estimate: 25%); middle value at least 1.5-fold (0.17 log units) away from the limit.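

No step can be read from compound 1 to compound 3, because both results are limits and not exact numbers: the limit of <= 100 nM in this assay, at which 2 of the 3 values shown sit.

The compounds shown leave open whether benzyl in place of 4-bromophenyl changes growth inhibition at all.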